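Changing the Aryl Ester on a Shared Core

The source may hold more compounds than are shown below. What is called first, only, known or untested is meant among the compounds shown, and "the series" means these compounds.

Of the compounds shown here, two have so far been tested in a functional assay on MCF7 cells (Homo sapiens) for antiproliferative activity, read by MTT assay, with a stated time of 72 h; a lower number here means a stronger inhibitor, a higher number a weaker inhibitor. In this assay compound 1 `CC1=CC[C@H]2[C@@H]1CC=C(C)[C@@H](CCC1=C(C)CC[C@@H]3OC(C)(C)[C@@H](O)CC[C@@]13C)C2(C)C` gives > 50000 nM, which is a limit of the assay rather than a number. Compound 1 thus sits at the limit of > 50000 nM in this assay, at which 1 of the 2 values shown sits. Among the compounds with values here, compound 2 `CC1=CC[C@H]2[C@H](CC[C@]2(C)O)C(C)(C)[C@@H]1CC[C@H]1[C@]2(C)CC[C@H](OC(=O)c3ccncc3)C(C)(C)O[C@H]2CC[C@@]1(C)O` gives 25300 nM in this assay, and this is the only actual number in the set, so compound 2 stands alone as the one compound with a measured value, and nothing can be said about its rank against compound 1 beyond that.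

Compound 3 `CC1=CC[C@H]2[C@H](CC[C@]2(C)O)C(C)(C)[C@@H]1CC[C@H]1[C@]2(C)CC[C@H](OC(=O)c3ccccc3C(F)(F)F)C(C)(C)O[C@H]2CC[C@@]1(C)O` has not yet been measured. It differs from compound 2 in a single place: 2-(trifluoromethyl)phenyl in place of pyridin-4-yl on a carbonyl carbon. Within the data shown here, no pair of measured compounds shows what such an exchange does in this assay, so there is no measured step to lean on.

For compound 3 the step from compound 2 is expected to be a 1.3-fold lower number from compound 2 to compound 3 (0.10 log units; within the scatter), a change that stays within the usual scatter, in no clear direction. Compound 3 is therefore estimated at 20000 nM in this assay, with a likely range from 5000 nM to 60000 nM.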

Compound 3, half-maximal inhibitory concentration: 19200 nM
The estimate for compound 3 lay 1.0-fold (0.02 log units) above the measured number, within the range that was stated.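

Within the data shown here, the first measured step at this position, 2-(trifluoromethyl)phenyl in place of pyridin-4-yl on a carbonyl carbon, reads in this assay as a 1.3-fold lower number from compound 2 to compound 3 (0.12 log units; within the scatter). The two esters therefore cannot be told apart in this test, even though the exchange swaps a ring with one nitrogen and one hydrogen-bond acceptor for a larger, carbon-only aromatic ring bearing fluorine and no hydrogen-bond acceptor. Nothing measured here accounts for this result.

This is one exchange on one shared core, so it does not show that every group on this carbonyl carbon would give a similar number, and the two compounds alone set no trend for the position. As far as these compounds go, it remains open whether an aromatic ring carrying an amine or a carboxylic acid, or a longer carbon chain in place of the ring, would give a number that stands clearly apart from those of compound 2 and compound 3.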